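The compounds below may be only part of what the source reports. "The series", "measured", "known", "first", "only" and "open" are said of these compounds alone.

Compound 1 `O=c1ccc2cc(OCc3cc(-c4ccccc4Cl)no3)ccc2o1` and compound 2 `COc1cccc(-c2cc(COc3ccc4oc(=O)ccc4c3)on2)c1` belong to the same series as the others, but in a functional assay on COLO 205 cells (Homo sapiens) for cytotoxicity, read by MTT assay, with a stated time of 48 h (a higher number here means a weaker inhibitor, a lower number a stronger inhibitor), compound 1 carries only the entry "not determined" (no result reported), and compound 2 likewise stands at "not determined" (no result reported). Among the measured compounds shown here, that leaves compound 3 `O=c1ccc2cc(OCc3cn(-c4ccccc4)nn3)ccc2o1` as the only member with a number: in this assay compound 3 gives 48800 nM, a weak result, and with nothing else measured there is no ranking to place it in.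

Compound 4 `COc1ccc(-n2cc(COc3ccc4oc(=O)ccc4c3)nn2)cc1` differs from compound 3 in one spot only, (methoxy in place of hydrogen on an aromatic carbon). For the measured compounds named here, no measured pair in this set shows what such a change does, so the expectation rests on compound 3 alone. A single methoxy group on a ring far from the shared core is the kind of change that usually moves a result little, so the step from compound 3 to compound 4 is expected to be a 1.2-fold lower number from compound 3 to compound 4 (0.07 log units; within the scatter), in no clear direction and not beyond the ordinary scatter. Compound 4 is therefore estimated at 42000 nM, with a plausible range from 15000 nM to 120000 nM.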

Compound 4, half-maximal inhibitory concentration: 32800 nM
For compound 4 the middle estimate is 1.3-fold (0.11 log units) above the measured one; low and high end bracket the measured number.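

Replacing hydrogen with methoxy, which turns phenyl into 4-methoxyphenyl, gives a 1.5-fold lower number from compound 3 to compound 4 (0.17 log units; within the scatter) in this assay. This first measured pair shows that a methoxy group at this place, on the six-membered aromatic ring and para to a large group, leaves the result within ordinary scatter, and both compounds remain weak. No further measurement is available to account for this outcome.

Among the compounds shown here, compounds 1 and 2 carry no numbers, so no steps involving them can be read, and the single pair says nothing about the other places on the molecule. On these data alone, it also remains open whether an amine, a carboxylic acid or a longer chain at this same place would move the result beyond the scatter, as a single methoxy group does not.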